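A Longer Selenocyanate Tether in Place of the Amide Link

A few compounds are considered here, and "the series" means these few. Any claim that something is new, unique, unknown or untested is made for them only; others in the source may bear on it.

Three compounds have numbers in a functional assay on A549 cells (Homo sapiens) for inhibition, read by MTT assay, with a stated time of 48 h; on this read-out higher numbers stand for weaker inhibition and lower numbers for stronger inhibition. For the measured compounds named here, compound 1 `Cc1nc(N(C)c2ccc([Se]C#N)c(Cl)c2)c2ccccc2n1` gives 7 nM, and compound 3 `Cc1nc(N(C)c2ccc([Se]C#N)c(F)c2)c2ccccc2n1` gives 4 nM; the only single-point step between measured compounds, a 1.8-fold lower number from compound 1 to compound 3 (0.24 log units; within the scatter), lies within the scatter, so these two cannot be ordered. Compound 2 `COc1ccc(N(C)c2nc(C)nc3ccccc23)cc1C(=O)NCC[Se]C#N` gives 187 nM, the highest of the three numbers and beyond the scatter from both others, so on these numbers compound 2 is the weakest inhibitor of the three.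

Compound 4 `COc1ccc(N(C)c2nc(C)nc3ccccc23)cc1OCCCCCC[Se]C#N` is built from compound 2 by a change at one place: a group of 10 heavy atoms (7 carbon, 1 nitrogen, 1 oxygen, 1 selenium; no ring) in place of a group of 8 heavy atoms (4 carbon, 2 nitrogen, 1 oxygen, 1 selenium; no ring), on an aromatic carbon. The amide link and its shorter chain leave; an ether link and a longer chain enter, with the selenocyanate kept at the end.

Going by the values given here, no measured step bears directly on this change. Among the compounds with values here, the one recorded step, a 1.8-fold lower number from compound 1 to compound 3 (0.24 log units; within the scatter), swaps halogens on a different part of the molecule and lies within the scatter, so it says nothing about lengthening or relinking the chain. The expectation therefore rests on compound 2, whose number in this assay is 187 nM. Compound 4 is estimated at 160 nM, with a range from 40 nM to 650 nM. That estimate means an expected step of a 1.2-fold lower number from compound 2 to compound 4 (0.07 log units; within the scatter), within the scatter.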

Compound 4, half-maximal inhibitory concentration: 5520 nM
Beside the measured number, compound 4's estimate is 35-fold (1.54 log units) below it, outside the stated range (above it).
By their numbers in this assay, from the lowest: compounds 3 and 1 (each within the scatter of the next); then compound 2; then compound 4.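

In this assay, the change gives a 30-fold higher number from compound 2 to compound 4 (1.47 log units; beyond the scatter), so the group on this aromatic carbon, ortho to a methoxy group, strongly affects the read-out, and here the ether link with its longer chain goes with much weaker inhibition than the amide link with its shorter chain. For the compounds shown here, the earlier compounds could not show this, since their only single-place step was a halogen swap elsewhere in the molecule, and that step lay within the scatter. Both compounds in the new step keep the selenocyanate at the chain end, so its presence alone does not guarantee a low number, and no measurement at hand explains why the number rose.

The link and the chain length changed together, so the compounds shown cannot say which of the two matters more; an amide link carrying the longer chain, or an ether link carrying a shorter one, would separate them. Also open, as far as these compounds go, is how a chain ending in a different group, such as a carboxylic acid or an amine, would compare with the selenocyanate at this position.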